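Replacing the amino linker of compound 3 with a direct aryl

A few compounds are considered here, and "the series" means these few. Any claim that something is new, unique, unknown or untested is made for them only; others in the source may bear on it.

Measured compounds:
Compound 1 `COc1cc(Cl)cc(-c2nn(-c3cccc(NC(=O)Nc4ccc(Cl)c(C(F)(F)F)c4)c3)cc2-c2ccncc2)c1`: -77%
Compound 2 `COc1cc(Cl)cc(-c2nn(-c3cccc(NC(=O)Nc4ccc(Cl)c(Cl)c4)c3)cc2-c2ccncc2)c1`: -68%
Compound 3 `COc1cc(Cl)cc(-c2nn(-c3cccc(NC(=O)Nc4cccc(C(F)(F)F)c4)c3)cc2-c2ccncc2)c1`: -99%

In a functional assay on SK-MEL-5 cells (Homo sapiens) for inhibition, read by sulforhodamine B assay, with a stated time of 48 h, tested at 100 uM (on this read-out higher numbers stand for a weaker effect at the one concentration tested and lower numbers for a stronger effect), compound 3 gives -99%, the lowest of the three numbers. Its steps to the others are both beyond the scatter: a number 22 percentage points lower from compound 1 to compound 3 (beyond the scatter) and a number 31 percentage points lower from compound 2 to compound 3 (beyond the scatter), while a number 9 percentage points higher from compound 1 to compound 2 (within the scatter) lies within it. Compound 4 `COc1cc(Cl)cc(-c2nn(-c3cccc(NC(=O)c4cccc(C(F)(F)F)c4)c3)cc2-c2ccncc2)c1` has not yet been measured in this assay. The change is 3-(trifluoromethyl)phenyl in place of (3-(trifluoromethyl)phenyl)amino on a carbonyl carbon. Among the compounds with values here, none of the measured steps touches this part of the molecule: all three measured compounds keep the (3-(trifluoromethyl)phenyl)amino group on the carbonyl carbon, and the measured changes concern only the substituents on the outer ring. The measured steps therefore give no direct guide, and the estimate rests on compound 3 alone. Compound 4 is expected to give -80%, within a wide range from -100% to -40%. This estimate means a step of a number 19 percentage points higher from compound 3 to compound 4 (beyond the scatter), somewhat toward a weaker effect than compound 3, but the direction is uncertain.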

Compound 4, a percentage reported as activity, at one concentration (the size of the read-out at that concentration, not a potency): 20%
The estimate for compound 4 lay 100 percentage points below the measured number; the whole stated range lies below it.
By their numbers in this assay, from the lowest: compound 3; then compounds 1 and 2 (each within the scatter of the next); then compound 4.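

This position turns out to weigh far more than the outer-ring substituents: a number 119 percentage points higher from compound 3 to compound 4 (beyond the scatter) in this assay, and the two other urea compounds give the same picture, with a number 88 percentage points higher from compound 2 to compound 4 (beyond the scatter) and a number 97 percentage points higher from compound 1 to compound 4 (beyond the scatter). The group leaving the carbonyl carbon carries a hydrogen-bond donor and the group entering carries none, and compound 4 is the only one of the four with a number above zero, so the effect seen at this concentration does not survive this change. Nothing shown here explains why the change has so large an effect.

From the compounds shown here alone, it remains open whether a methylene or an ether oxygen on the carbonyl carbon would keep any of the effect of compound 3. Going by these compounds, it is also open whether the 3,4-dichlorophenyl or 4-chloro-3-(trifluoromethyl)phenyl groups would behave differently when attached directly.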